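A few compounds are considered here, and "the series" means these few. Any claim that something is new, unique, unknown or untested is made for them only; others in the source may bear on it.

Measured compounds:
Compound 1 `COc1cccc(/C=N/c2ccc(OCc3ccccc3)cc2)c1O` — in a functional assay, with a stated time of 30 min (on this read-out lower numbers stand for stronger inhibition and higher numbers for weaker inhibition), compound 1 is reported only as a limit, > 200000 nM (the limit of > 200000 nM in this assay, at which 1 of the 3 values shown sits).
Compound 2 `Oc1cccc(/C=N/c2ccc(OCc3ccccc3)cc2)c1O` — compound 2 gives 13300 nM.
Compound 3 `Oc1ccc(/C=N/c2ccc(OCc3ccccc3)cc2)c(O)c1O` — compound 3 gives 43400 nM.

Among the two actual numbers, compound 2 stands lowest; compound 3 is its nearest neighbour, while compound 1 contributes only a limit. The step of an at least 15-fold lower number from compound 1 to compound 2 (1.17 log units; beyond the scatter) shows that freeing a hydroxy on the ring attached to the carbon double-bonded to nitrogen matters greatly. The step of a 3.3-fold higher number from compound 2 to compound 3 (0.51 log units; beyond the scatter) shows that a further hydroxy on that ring weakens compound 3 moderately.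

Compound 4 `Oc1ccc(F)cc1/C=N/c1ccc(OCc2ccccc2)cc1` has not yet been measured in this assay. Its change from compound 2 is 5-fluoro-2-hydroxyphenyl in place of 2,3-dihydroxyphenyl on a carbon with a double bond to nitrogen: one of the two hydroxy groups of the 2,3-dihydroxyphenyl is gone, and a fluorine appears. Going by the values given here, neither measured step matches this exactly, but the large loss from capping a hydroxy in compound 1 suggests the remaining single hydroxy may not suffice, and no measured compound shows the effect of fluorine. Compound 4 is therefore expected to give a higher number than compound 2, a step of about a 4.5-fold higher number from compound 2 to compound 4 (0.65 log units; beyond the scatter). The estimate for compound 4 is 60000 nM, within a range from 15000 nM to 200000 nM.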

Compound 4, half-maximal inhibitory concentration: > 200000 nM
Compound 4 gave a limit, no number; the forecaster's own chance of this, stated with the estimate: 30%; middle value at least 3.3-fold (0.52 log units) from the limit.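

The step of an at least 15-fold higher number from compound 2 to compound 4 (1.17 log units; beyond the scatter) shows that, on the carbon with a double bond to nitrogen, 5-fluoro-2-hydroxyphenyl cannot stand in for 2,3-dihydroxyphenyl, even though one hydroxy remains on the ring. Compound 4 is reported only as a limit, and it now shares that limit with compound 1: the limit of > 200000 nM in this assay, at which 2 of the 4 values shown sit. Among the four compounds, the two with a single free hydroxy on this ring give only the limit, while compound 2 and compound 3, with more than one, give actual numbers.

Since one hydroxy leaves and a fluorine enters in the same change, the compounds shown cannot separate the loss of the hydroxy from the arrival of the fluorine. They also leave open how this ring would fare with an amine or a carboxylic acid in place of the second hydroxy.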